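Swapping the benzamide ring of compound 2

The source may hold more compounds than are shown below. What is called first, only, known or untested is meant among the compounds shown, and "the series" means these compounds.

Compounds measured so far:
compound 1 `CNc1nc(Nc2ccc(C)c([N+](=O)[O-])c2)ncc1C(=O)Nc1cc(NC(=O)c2cccc(C(F)(F)F)c2)ccc1C` — 52 nM
compound 2 `CNc1nc(Nc2ccc(C)c(N)c2)ncc1C(=O)Nc1cc(NC(=O)c2cccc(C(F)(F)F)c2)ccc1C` — 14 nM
compound 3 `Cc1ccc(Nc2ncc(C(=O)Nc3cc(NC(=O)c4cccc(C(F)(F)F)c4)ccc3C)c(N(C)C)n2)cc1N` — 1210 nM

In a functional assay on K562 cells (Homo sapiens) for antiproliferative activity, read by CellTiter-Glo and CCK-8 assay, with a stated time of 72 h (on this read-out higher numbers stand for weaker inhibition of growth and lower numbers for stronger inhibition of growth), compound 2 gives the lowest number of the three. The step of a 3.7-fold lower number from compound 1 to compound 2 (0.57 log units; beyond the scatter) separates it from compound 1, and the step of an 86-fold higher number from compound 2 to compound 3 (1.94 log units; beyond the scatter) separates it from compound 3.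

Compound 4 `CNc1nc(Nc2ccc(C)c(N)c2)ncc1C(=O)Nc1cc(NC(=O)c2ccc(OC)cc2)ccc1C` differs from compound 2 by 4-methoxyphenyl in place of 3-(trifluoromethyl)phenyl on a carbonyl carbon. Neither measured step touches this part of the molecule: one changes a group on the other aromatic ring, the other a substituent on a ring nitrogen. There is thus no direct guide, and the expectation must remain wide.

Compound 4 is expected to be somewhat weaker, estimated at 150 nM (range 30 nM to 1500 nM), a step of an 11-fold higher number from compound 2 to compound 4 (1.03 log units; beyond the scatter).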

Compound 4, concentration for 50% growth inhibition: 610 nM
The estimate for compound 4 lay 4.1-fold (0.61 log units) below the measured number; the measured number falls inside the stated range.
By their numbers in this assay, from the lowest: compound 2; then compound 1; then compounds 4 and 3 (each within the scatter of the next).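

In this assay, among the compounds shown here, the group on the carbonyl carbon, which the earlier compounds left unchanged, proves to matter, with 4-methoxyphenyl in place of 3-(trifluoromethyl)phenyl giving a 44-fold higher number from compound 2 to compound 4 (1.64 log units; beyond the scatter). This swap alters both the substituent and where it sits on the ring, so the step cannot be assigned to either alone. Nothing measured here explains the step.

On these data alone, it remains open how a 3-methoxyphenyl or a 4-(trifluoromethyl)phenyl group on the same carbonyl carbon would read. Also open, as far as these compounds go, is whether a chlorine atom or a nitrile could stand in for trifluoromethyl.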